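Aryl in place of hexylsulfanyl at the benzylamide position

This account rests on a few compounds, and the source may have more. Where it says the series, first, only, none or still open, it means among the compounds named here.

Compounds measured so far:
compound 1, `CC(C(=O)NCc1ccc(C(F)(F)F)cc1N1CCCCCC1)c1ccc(NS(C)(=O)=O)c(F)c1`, 1.6 nM in an assay on CHO cells for antagonist activity at transient receptor potential cation channel subfamily V member 1 (Homo sapiens), read by FLIPR; a higher number here means a weaker inhibitor, a lower number a stronger inhibitor
compound 2, `CCCCCCSc1cc(C(F)(F)F)ccc1CNC(=O)C(C)c1ccc(NS(C)(=O)=O)c(F)c1`, 1.8 nM in this assay

Among the measured compounds shown here, compound 2 stands with compound 1 inside the usual scatter of this assay: the step of a 1.1-fold higher number from compound 1 to compound 2 (0.05 log units; within the scatter) is the only measured step, and it separates the two numbers by nothing that can be read as a difference. The two substituents on that aromatic carbon, a saturated ring of nitrogen and carbon and an open chain on sulfur, give the same outcome.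

Compound 3, `CC(C(=O)NCc1ccc(C(F)(F)F)cc1-c1cccc(F)c1)c1ccc(NS(C)(=O)=O)c(F)c1`, is not yet measured. The change from compound 2 is 3-fluorophenyl in place of hexylsulfanyl on an aromatic carbon. For the measured compounds named here, no measured step introduces an aromatic ring at this carbon; the one step that bears on it, a 1.1-fold higher number from compound 1 to compound 2 (0.05 log units; within the scatter), shows only that two quite different groups there are tolerated equally. On that basis a step within the scatter, or a modest weakening, is expected for a 1.7-fold higher number from compound 2 to compound 3 (0.22 log units; within the scatter). The expected value for compound 3 in this assay is 3 nM, with a range from 0.8 nM to 12 nM.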

Compound 3, inhibition constant: 1.9 nM
Estimate against measurement, compound 3: 1.6-fold (0.20 log units) above, within the range that was stated.
By their numbers in this assay, from the lowest: compounds 1, 2 and 3 (each within the scatter of the next).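

In this assay, an aromatic ring on this aromatic carbon, meta to a trifluoromethyl group, reads the same as the two earlier substituents: a 1.1-fold higher number from compound 2 to compound 3 (0.02 log units; within the scatter) and a 1.2-fold higher number from compound 1 to compound 3 (0.07 log units; within the scatter). Azepan-1-yl, hexylsulfanyl and 3-fluorophenyl now share this carbon with no readable difference, although they attach through nitrogen, sulfur and carbon and range from a saturated ring through an open chain to an aromatic ring of carbon only, so neither the attaching atom nor the type of substituent separates these three compounds in this assay. Nothing measured here explains why the three substituents give the same outcome.

Open, from the compounds shown here alone, is whether a much smaller substituent, such as a single hydrogen or a methyl, or a group of another kind, such as an amine or a carboxylic acid, on this carbon would stay within the same narrow band of numbers. Also open, going by these compounds, is whether an unsubstituted phenyl or a pyridine ring would read the same as 3-fluorophenyl, which would show whether the fluorine has any part in the result.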